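Pyrazole nitrogen substituent series, next step

The compounds below may be only part of what the source reports. "The series", "measured", "known", "first", "only" and "open" are said of these compounds alone.

Of the compounds shown here, two of the shared core have been measured in a functional assay on NCI-H2286 cells (Homo sapiens) for antiproliferative activity, read by CCK-8 assay, with a stated time of 72 h; on this read-out higher numbers stand for weaker inhibition and lower numbers for stronger inhibition. Compound 1 `CCn1cc(-c2n[nH]c3cc(-c4cc(C(=O)Nc5cccc(C(F)(F)F)c5)ccc4C)ccc23)cn1` gives 19.8 nM. Within the data shown here, compound 2 `Cc1ccc(C(=O)Nc2cccc(C(F)(F)F)c2)cc1-c1ccc2c(-c3cnn(CC(C)O)c3)n[nH]c2c1` gives 196 nM, the highest of the two numbers; the one step between them, a 9.9-fold higher number from compound 1 to compound 2 (1.00 log units; beyond the scatter), shows that the substituent on the aromatic nitrogen moves the read-out well beyond the scatter.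

Compound 3 `Cc1ccc(C(=O)Nc2cccc(C(F)(F)F)c2)cc1-c1ccc2c(-c3cnn(C4CCN(C)CC4)c3)n[nH]c2c1` is not yet measured. It differs from compound 2 in the same place: 1-methylpiperidin-4-yl in place of 2-hydroxypropyl on an aromatic nitrogen. Among the measured compounds shown here, the only step that bears on this position is a 9.9-fold higher number from compound 1 to compound 2 (1.00 log units; beyond the scatter), where the smaller group gave the lower number. For the measured compounds named here, no measured step carries the 1-methylpiperidin-4-yl group, so its direction rests on that single comparison alone. The expectation is a moderate lower number for compound 3 relative to compound 2, not reaching compound 1, because a 9.9-fold higher number from compound 1 to compound 2 (1.00 log units; beyond the scatter) sets the span that a change at this nitrogen has covered so far; the estimated step is a 3.3-fold lower number from compound 2 to compound 3 (0.51 log units; beyond the scatter).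

Compound 3 is therefore estimated at 60 nM, with a range of 15 nM to 250 nM.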

Compound 3, half-maximal inhibitory concentration: 56.5 nM
Compound 3: the middle estimate sits 1.1-fold (0.03 log units) above what was measured; measured number inside the range.
By their numbers in this assay, from the lowest: compound 1; then compound 3; then compound 2.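

In this assay, the change on the aromatic nitrogen gives a 3.5-fold lower number from compound 2 to compound 3 (0.54 log units; beyond the scatter), so the larger group, with 7 heavy atoms against 4, carries the lower number, and compound 2 goes against any reading of the earlier step as a simple order by size. Ethyl still holds the lowest number of the three, with a 2.9-fold higher number from compound 1 to compound 3 (0.46 log units; beyond the scatter), so this position accepts a six-membered non-aromatic ring with a hetero atom and the number stays within the span set by the other two groups, without reaching that of compound 1. No measurement is available that explains the order of these three substituents.

The compounds shown do not separate the parts of the change: a plain propyl chain would test the hydroxyl of the 2-hydroxypropyl group, while cyclohexyl and piperidin-4-yl without the methyl would test the ring nitrogen and its methyl. On these data alone, whether anything smaller than ethyl, such as methyl or a bare hydrogen on that nitrogen, gives a lower number than compound 1 also remains open.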